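Swapping the aryl on the alkene of a bromophenyl enone

This account rests on a few compounds, and the source may have more. Where it says the series, first, only, none or still open, it means among the compounds named here.

Measured compounds in a functional assay on DU-145 cells (Homo sapiens) for inhibition, read by trypan blue exclusion, with a stated time of 96 h; a lower number here means a stronger inhibitor of growth, a higher number a weaker inhibitor of growth:
compound 1 `O=C(/C(=C\c1ccc(Cl)cc1)S(=O)(=O)c1ccc(Br)cc1)c1ccc(Br)cc1` gives 50000 nM
compound 2 `O=C(/C(=C\c1ccc(F)cc1Cl)Sc1ccc(Br)cc1)c1ccc(Br)cc1` gives 1000 nM
compound 3 `O=C(/C(=C\c1ccc(F)cc1Cl)S(=O)(=O)c1ccc(Br)cc1)c1ccc(Br)cc1` gives 50000 nM

Compound 2 stands lowest of the three; its nearest neighbour is compound 1, and the gap to both compound 1 and compound 3 lies beyond the scatter. How the core of compound 2 differs from the core of compound 3 is not broken down here.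

Within the core shared by compound 1 and compound 3, one change has been measured: 4-chlorophenyl in place of 2-chloro-4-fluorophenyl on a double-bonded chain carbon bound to a double-bonded chain carbon The step of no change at the digits printed from compound 3 to compound 1 (within the scatter) was flat.

The same kind of change now leads from compound 2 to compound 4 `O=C(/C(=C\c1ccc(Cl)cc1)Sc1ccc(Br)cc1)c1ccc(Br)cc1`: 4-chlorophenyl in place of 2-chloro-4-fluorophenyl on a double-bonded chain carbon bound to a double-bonded chain carbon

Because the earlier step of no change at the digits printed from compound 3 to compound 1 (within the scatter) showed no movement, compound 4 is expected to stay close to compound 2, and its step of a 1.5-fold higher number from compound 2 to compound 4 (0.18 log units; within the scatter) is estimated to lie within the scatter. The only support is that single step on a different core, so the range is kept wide. Compound 4 is therefore estimated at 1500 nM in this assay, with a span from 400 nM to 8000 nM.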

Compound 4, concentration for 50% growth inhibition: 1000 nM
For compound 4 the middle estimate is 1.5-fold (0.18 log units) above the measured one; low and high end bracket the measured number.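

In this assay, putting 4-chlorophenyl in place of 2-chloro-4-fluorophenyl on a double-bonded chain carbon bound to a double-bonded chain carbon gave no change at the digits printed from compound 2 to compound 4 (within the scatter), and this agrees with the same change on the other core: the same change on two cores in this assay, no change at the digits printed (within the scatter) from compound 3 to compound 1 and no change at the digits printed (within the scatter) from compound 2 to compound 4, 1.0-fold (0.00 log units) apart, within the scatter of two such steps. On the two cores shown, then, the change carries over as a flat step, and the gap between the cores of compound 2 and compound 3 plays no visible part in how this swap reads. Among the compounds shown here, this rests on only two pairs of compounds, so it does not show that the swap would stay flat on a third core, nor does it show that any other change at this place would transfer in the same way.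

The compounds shown leave open how a group other than these two halogenated phenyl rings would fare at this place, such as a phenyl ring carrying an amine or a carboxylic acid, or a longer alkyl chain. They also leave open whether the flat step holds in any other cell line.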